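A few compounds are considered here, and "the series" means these few. Any claim that something is new, unique, unknown or untested is made for them only; others in the source may bear on it.

Working notes on the series in a toxicity assay on NIH3T3 cells (Mus musculus) for cytotoxicity, read by resazurin assay; on this read-out lower numbers stand for an effect already at smaller amounts and higher numbers for an effect only at larger amounts of compound.

Compound 1, `COC(=O)c1ccc(NCc2cncn2Cc2ccccc2C(C)(C)C)cc1-c1ccccc1`, carries the shared core with a 2-(tert-butyl)benzyl group on the imidazole nitrogen. For compound 1 this assay reports "not determined" (no result reported), so no number stands for it and its position within the series cannot be placed. Two related compounds have results, each only as a limit of the assay. Compound 2, `Nc1cc(-c2ccccc2)ccc1Cn1cncc1CNc1ccc(-c2cncs2)c(-c2ccccc2)c1`, gives > 1000 nM in this assay, a limit rather than a number. Compound 3, `c1ccc(Cn2cncc2CNc2cccc(-c3ccccc3)c2)cc1`, gives > 750 nM in this assay, again a limit rather than a number. Both limits, the limit of > 1000 nM in this assay, at which 1 of the 3 values shown sits, and (the limit of > 750 nM in this assay, at which 1 of the 3 values shown sits), say only that no cytotoxic effect was seen up to the highest amount tested.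

Compound 4, `COC(=O)c1ccc(NCc2cncn2Cc2ccc(C#N)cc2)cc1-c1ccccc1`, differs from compound 1 in one place: 4-cyanophenyl in place of 2-(tert-butyl)phenyl on a saturated chain carbon bound to an aromatic nitrogen. Going by the values given here, no measured step in this assay pairs with this change, so its direction is unknown; with the two limits as the only reference, no effect beyond the scatter is expected in either direction.

For compound 4 in this assay the expected result is 1200 nM, within a range from 500 nM to 5000 nM, and it is estimated that the assay will most likely again report only a limit.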

Compound 4, half-maximal effective concentration: > 10000 nM
Compound 4: no number, only a limit (the forecaster's own chance of this, stated with the estimate: 70%); middle value at least 8.3-fold (0.92 log units) away from the limit.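

In this assay compound 4 gives > 10000 nM, a limit of the assay and not a number. Going by these compounds alone, compound 1 has no number either, so no step between compound 1 and compound 4 can be read. The compounds shown leave open whether 2-(tert-butyl)benzyl and 4-cyanobenzyl differ in this read-out, and at what concentration any cytotoxic effect would appear.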